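Changing the ring on the side chain of compound 2

The source may report more compounds than this note shows. Statements on the series, on what has been measured and on what is new or still open speak of the compounds shown alone.

In a functional assay on HCT-116 cells (Homo sapiens) for cytotoxicity, read by MTT assay, with a stated time of 72 h; on this read-out higher numbers stand for weaker inhibition and lower numbers for stronger inhibition:
Compound 1 `COc1ncc(-c2ccc3nc(NC(=O)N(C)C)nn3c2)cc1NS(=O)(=O)c1ccc(F)cc1`: 760 nM
Compound 2 `COc1ncc(-c2ccc3nc(NC(=O)NCCN4CCCCC4)nn3c2)cc1NS(=O)(=O)c1ccc(F)cc1`: 150 nM
Compound 3 `CCN(CC)CCNC(=O)Nc1nc2ccc(-c3cnc(OC)c(NS(=O)(=O)c4ccc(F)cc4F)c3)cn2n1`: 140 nM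

Compound 2 stands level with compound 3, within the scatter, and well under compound 1. Compound 4 `COc1ncc(-c2ccc3nc(NC(=O)NCCN4CCN(C)CC4)nn3c2)cc1NS(=O)(=O)c1ccc(F)cc1` differs from compound 2 in one place: 4-methylpiperazin-1-yl in place of piperidin-1-yl on a saturated chain carbon, two bonds along the chain from an amide-type nitrogen. Within the data shown here, the only measured step that bears on this is a 5.1-fold lower number from compound 1 to compound 2 (0.70 log units; beyond the scatter). It was modest and replaced dimethylamino with (2-(piperidin-1-yl)ethyl)amino on a carbonyl carbon, so it leaves the ring itself untested. Swapping one ring for the other at the chain end is therefore expected to move this assay little, with no step beyond the scatter. The expected step is a 1.1-fold higher number from compound 2 to compound 4 (0.05 log units; within the scatter). Compound 4 is estimated at 170 nM, with an expected range of 70 nM to 400 nM.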

Compound 4, half-maximal inhibitory concentration: 260 nM
Beside the measured number, compound 4's estimate is 1.5-fold (0.18 log units) below it; measured number inside the range.
By their numbers in this assay, from the lowest: compounds 3, 2 and 4 (each within the scatter of the next); then compound 1.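

In this assay, the chain end accepted a second ring nitrogen: 4-methylpiperazin-1-yl in place of piperidin-1-yl gave a step within the scatter (a 1.7-fold higher number from compound 2 to compound 4 (0.24 log units; within the scatter)). The advantage over dimethylamino on the carbonyl carbon also held with this new ring, beyond the scatter (a 2.9-fold lower number from compound 1 to compound 4 (0.47 log units; beyond the scatter)). No evidence here accounts for either step. The compounds shown leave open how a morpholin-4-yl ring at this chain end, or a 3-(piperidin-1-yl)propyl chain with its longer linker, would read in this assay.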